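Swapping the amide-nitrogen substituent on the shared core

A few compounds are considered here, and "the series" means these few. Any claim that something is new, unique, unknown or untested is made for them only; others in the source may bear on it.

Compound 1 `O=C(CCC(=O)OCCCCCCSc1ccc([N+](=O)[O-])c2nonc12)Nc1cccc(Cl)c1` carries the highest number of the three measured compounds in a functional assay on A549 cells (Homo sapiens) for inhibition, read by MTT assay, with a stated time of 72 h (on this read-out higher numbers stand for weaker inhibition and lower numbers for stronger inhibition), giving 5290 nM, though every gap to it lies within the scatter. Compound 2 `Cc1ccc(NC(=O)CCC(=O)OCCCCCCSc2ccc([N+](=O)[O-])c3nonc23)cc1` gives 5240 nM and compound 3 `O=C(CCC(=O)OCCCCCCSc1ccc([N+](=O)[O-])c2nonc12)Nc1ccc(F)c(Cl)c1` gives 3210 nM; the steps of a 1.0-fold lower number from compound 1 to compound 2 (0.00 log units; within the scatter), a 1.6-fold lower number from compound 2 to compound 3 (0.21 log units; within the scatter) and a 1.6-fold lower number from compound 1 to compound 3 (0.22 log units; within the scatter) all stay within the scatter, so the three substituted phenyl groups are not separated here. Compound 4 `O=C(CCC(=O)OCCCCCCSc1ccc([N+](=O)[O-])c2nonc12)NCCN1CCCC1` differs from compound 1 by 2-(pyrrolidin-1-yl)ethyl in place of 3-chlorophenyl on an amide-type nitrogen. Within the data shown here, no measured step exchanges the aromatic group on the amide-type nitrogen for a non-aromatic one, so the measured steps bear on it only loosely; they show the substituent at that position tolerating change. The step of a 1.1-fold lower number from compound 1 to compound 4 (0.02 log units; within the scatter) is therefore expected to lie within the scatter. Compound 4 is expected to give an estimated 5000 nM, within 1700 nM to 15000 nM.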

Compound 4, half-maximal inhibitory concentration: 3240 nM
The estimate for compound 4 lay 1.5-fold (0.19 log units) above the measured number; low and high end bracket the measured number.
By their numbers in this assay, from the lowest: compounds 3, 4, 2 and 1 (each within the scatter of the next).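

In this assay, among these compounds, the first non-aromatic group on the amide-type nitrogen, 2-(pyrrolidin-1-yl)ethyl, is not separated from any of the three substituted phenyl groups: the steps (a 1.6-fold lower number from compound 1 to compound 4 (0.21 log units; within the scatter)), (a 1.6-fold lower number from compound 2 to compound 4 (0.21 log units; within the scatter)) and (a 1.0-fold higher number from compound 3 to compound 4 (0.00 log units; within the scatter)) all stay within the scatter. The position therefore takes a non-aromatic ring with one hetero atom as well as an aromatic ring of carbon only, with no step beyond the scatter. No evidence on hand bears on this result.

Open, going by these compounds, is whether a carboxylic acid or a dimethylamino group at this position stays within the scatter. Also open, on these data alone, is whether a longer chain in place of the ethyl does so.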